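Methylsulfanyl in place of benzyloxy near the cytotoxicity ceiling

A few compounds are considered here, and "the series" means these few. Any claim that something is new, unique, unknown or untested is made for them only; others in the source may bear on it.

Working notes on the series. In an ADME assay on HFF cells (Homo sapiens) for cytotoxicity, with a stated time of 8 days (on this read-out lower numbers stand for higher toxicity in this test and higher numbers for lower toxicity in this test), compound 1 `CNc1nc(N)nc2c1ncn2/C=C1/CC1(CO)CO` gives 265000 nM. Compound 2 `CCCCCCCCOc1nc(N)nc2c1ncn2/C=C1/CC1(CO)CO` is reported only as a limit of the assay, > 300000 nM. Compound 3 `Nc1nc(OCc2ccccc2)c2ncn(/C=C3/CC3(CO)CO)c2n1` is likewise reported only as a limit, > 300000 nM. Compound 3 therefore stands at the limit of > 300000 nM in this assay, at which 2 of the 3 values shown sit, and no number is known for it. The step of an at least 1.1-fold higher number from compound 1 to compound 2 (0.05 log units; that floor lies within the scatter) and the step of an at least 1.1-fold higher number from compound 1 to compound 3 (0.05 log units; that floor lies within the scatter) are both floors that lie within the scatter, and the step that the two limits leave unreadable from compound 2 to compound 3 cannot be read from two limits. Compound 4 `CSc1nc(N)nc2c1ncn2/C=C1/CC1(CO)CO` is not yet measured in this assay; it differs from compound 3 by methylsulfanyl in place of benzyloxy on an aromatic carbon. The only readable bearings come from compound 1, whose small group gives a finite value close to the ceiling, and from the steps away from compound 1, which stay within the scatter. The expected step is an at least 1.1-fold lower number from compound 3 to compound 4 (0.04 log units; that floor lies within the scatter), none beyond the scatter. Compound 4 is therefore estimated at 270000 nM, with a range from 150000 nM to 400000 nM, and a finite value or a limit are both plausible.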

Compound 4, half-maximal cytotoxic concentration: > 300000 nM
Compound 4: only a limit was reported (the forecaster's own chance of this, stated with the estimate: 40%); at least 1.1-fold (0.04 log units) between middle value and limit.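

In this assay compound 4 is reported only as a limit, > 300000 nM. Among these compounds, this shows that a group of 2 heavy atoms on this aromatic carbon can reach the same limit as the larger octyloxy and benzyloxy groups, while the one readable comparison, methylsulfanyl in place of methylamino, gives an at least 1.1-fold higher number from compound 1 to compound 4 (0.05 log units; that floor lies within the scatter). The steps from compound 2 and from compound 3 to compound 4 join two limits and cannot be read, and the series now gathers at a single ceiling: the limit of > 300000 nM in this assay, at which 3 of the 4 values shown sit.

From the compounds shown here alone, how an amine or a carboxylic acid on this aromatic carbon would read in this assay stays open. Also open, going by these compounds, is whether any group here gives a value clearly apart from the limit, and how compound 2, compound 3 and compound 4 would order if a number were available for each.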